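Swapping the 2-methylphenyl group on a sulfonamide nitrogen

The source may report more compounds than this note shows. Statements on the series, on what has been measured and on what is new or still open speak of the compounds shown alone.

- Compound 1 `O=C(/C=C/c1cccnc1)NCCCCCCCc1cccc(S(=O)(=O)Nc2ccccc2)c1` gives 42.6 nM 
- Compound 2 `Cc1ccccc1NS(=O)(=O)c1cccc(CCCCCCNC(=O)/C=C/c2cccnc2)c1` gives 0.226 nM 

Both values come from a functional assay on MCF7 cells (Homo sapiens) for inhibition, read by CCK-8 assay, with a stated time of 72 h (on this read-out higher numbers stand for weaker inhibition and lower numbers for stronger inhibition), and compound 2 stands lowest of the two at 0.226 nM while compound 1 lies at 42.6 nM with a gap well beyond the scatter. Compound 3 `O=C(/C=C/c1cccnc1)NCCCCCCc1cccc(S(=O)(=O)Nc2ccc(F)c(Cl)c2)c1` is still unmeasured in this assay and differs from compound 2 by carrying 3-chloro-4-fluorophenyl in place of 2-methylphenyl on a sulfonamide nitrogen. Within the data shown here, compound 1 and compound 2 differ in more than one place, so no measured step isolates this exchange. Among the measured compounds shown here, since compound 2 at 0.226 nM already holds the lower of only two numbers, a moderate rise beyond the scatter is expected in this assay rather than a further fall, although the data cannot exclude a smaller change. The estimated move is a 5.3-fold higher number from compound 2 to compound 3 (0.73 log units; beyond the scatter) toward weaker inhibition. For compound 3 the expected value is 1.2 nM with an estimated range from 0.12 nM to 12 nM as the measurement is awaited.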

Compound 3, half-maximal inhibitory concentration: 6.3 nM
For compound 3 the middle estimate is 5.3-fold (0.72 log units) below the measured one; the measured number falls inside the stated range.
By their numbers in this assay, from the lowest: compound 2; then compound 3; then compound 1.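

In this assay, among these compounds, replacing 2-methylphenyl with 3-chloro-4-fluorophenyl on a sulfonamide nitrogen gives a 28-fold higher number from compound 2 to compound 3 (1.45 log units; beyond the scatter), and this is the first measured step that isolates a change at this position. It shows that the position is sensitive to which aryl group it carries: with the rest of the molecule unchanged, two groups that each have one six-membered aromatic ring of carbon only and no hydrogen-bond donors or acceptors still separate by a large margin, although compound 3 remains at 6.3 nM in this assay. Nothing at hand explains why the two groups differ.

As far as these compounds go, because the step exchanges whole groups, it remains open whether the loss of the methyl, the arrival of the chlorine or the arrival of the fluorine accounts for the change, and compound 1 cannot settle this since it differs from compound 2 in more than one place. From the compounds shown here alone, how a methoxy group, a nitrile or a carboxylic acid on this aryl ring would read also remains open.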